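Compound 4: a 3-bromophenyl change in the series

The compounds below may be only part of what the source reports. "The series", "measured", "known", "first", "only" and "open" are said of these compounds alone.

In a functional assay on A549 cells (Homo sapiens) for inhibition, read by sulforhodamine B assay, with a stated time of 72 h (a lower number here means a stronger inhibitor, a higher number a weaker inhibitor), compound 2 (`COc1cc2c(Nc3ccc(F)c(Cl)c3)ncnc2cc1OCCOCCn1ccnc1[N+](=O)[O-]`) gives 7640 nM, compound 1 (`COc1cc2c(Nc3ccc(F)c(Cl)c3)ncnc2cc1OCCCCCCn1ccnc1[N+](=O)[O-]`) gives 6520 nM and compound 3 (`COc1cc2c(Nc3ccc(OCc4cccc(F)c4)c(Cl)c3)ncnc2cc1OCCOCCn1ccnc1[N+](=O)[O-]`) gives 6230 nM. All three values lie within the scatter of one another, so compound 2 stands level with the other two.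

Compound 4 (`COc1cc2c(Nc3cccc(Br)c3)ncnc2cc1OCCOCCn1ccnc1[N+](=O)[O-]`) departs from compound 2 by a single change: 3-bromophenyl in place of 3-chloro-4-fluorophenyl on a nitrogen on an aromatic ring. In words, 3-bromophenyl stands in place of 3-chloro-4-fluorophenyl on a nitrogen on an aromatic ring.

The nearest evidence is a 1.2-fold lower number from compound 2 to compound 3 (0.09 log units; within the scatter), where (3-fluorobenzyl)oxy replaced fluoro on an aromatic carbon and the shift stayed within the scatter. The chain change, a 1.2-fold higher number from compound 1 to compound 2 (0.07 log units; within the scatter), lies elsewhere in the structure and also stayed within the scatter. Among the measured compounds shown here, no measured compound carries the 3-bromophenyl group, so this support is indirect.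

No shift beyond the scatter is expected in this assay, and the expected step is a 1.2-fold lower number from compound 2 to compound 4 (0.07 log units; within the scatter). Compound 4 is estimated at 6500 nM, with an expected range of 3300 nM to 12500 nM.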

Compound 4, half-maximal inhibitory concentration: 10100 nM
Estimate against measurement, compound 4: 1.6-fold (0.19 log units) below; the measured number falls inside the stated range.
By their numbers in this assay, from the lowest: compounds 3, 1, 2 and 4 (each within the scatter of the next).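

In this assay the whole aryl group on the nitrogen can be exchanged without a shift beyond the scatter: the step is a 1.3-fold higher number from compound 2 to compound 4 (0.12 log units; within the scatter). Among the compounds shown here, the earlier compounds showed only a replacement of the fluoro group and a change in the chain, so this is the first change that removes both halogens of the 3-chloro-4-fluorophenyl group and brings in 3-bromophenyl. Nothing available explains this step, and it is read here only as a number.

Because the fluoro and chloro groups leave together, the step does not separate the two, and 3-chlorophenyl or 4-fluorophenyl on the same nitrogen would do so. Also open, going by these compounds, is whether any group at this place moves the number beyond the scatter, for example a phenyl ring carrying a carboxylic acid or 3-ethynylphenyl.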